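From Nitro to Trifluoromethyl: What to Expect

The source may hold more compounds than are shown below. What is called first, only, known or untested is meant among the compounds shown, and "the series" means these compounds.

Compound 1 `N#CC1CN1C(=O)Nc1ccc(F)cc1` gives 6200 nM in a functional assay on A549 cells (Homo sapiens) for inhibition; on this read-out lower numbers stand for stronger inhibition and higher numbers for weaker inhibition.
Compound 2 `N#CC1CN1C(=O)Nc1ccc([N+](=O)[O-])cc1` gives 3900 nM in this assay.
Compound 3 `N#CC1CN1C(N)=O` reaches only a limit of > 280000 nM in this assay, which is not a number.

Within the data shown here, compound 2 holds the lowest of the two numbers given, and the step from compound 1 to it, a 1.6-fold lower number from compound 1 to compound 2 (0.20 log units; within the scatter), stays within the scatter; the value of compound 3 is a limit and supports no step. Compound 4 `N#CC1CN1C(=O)Nc1ccc(C(F)(F)F)cc1` differs from compound 2 by trifluoromethyl in place of nitro on an aromatic carbon. Among the measured compounds shown here, the one measured step, a 1.6-fold lower number from compound 1 to compound 2 (0.20 log units; within the scatter), also exchanged a single group at the same place and moved nothing beyond the scatter. Nothing measured concerns trifluoromethyl itself. The author therefore expects no step beyond the scatter, a 1.3-fold higher number from compound 2 to compound 4 (0.11 log units; within the scatter). Compound 4 is estimated at 5000 nM, between 1500 nM and 17000 nM.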

Compound 4, half-maximal inhibitory concentration: 4300 nM
Compound 4: middle estimate off by 1.2-fold (0.07 log units), on the high side; the measured number falls inside the stated range.
By their numbers in this assay, from the lowest: compounds 2, 4 and 1 (each within the scatter of the next). At a limit, above all of these: compound 3.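

In this assay, trifluoromethyl adds a third group at this aromatic carbon, and it does not separate from the other two: a 1.1-fold higher number from compound 2 to compound 4 (0.04 log units; within the scatter), and a 1.4-fold lower number from compound 1 to compound 4 (0.16 log units; within the scatter). Fluoro, nitro and trifluoromethyl therefore read alike here, which the single earlier step could not show for a third group. Nothing shown gives a cause for this sameness.

From the compounds shown here alone, whether an amine, a carboxylic acid or a longer chain at this aromatic carbon would also read alike stays open. The pattern holds only for compounds 1, 2 and 4.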